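Amino for chloro on the pendant phenyl of compound 3

A few compounds are considered here, and "the series" means these few. Any claim that something is new, unique, unknown or untested is made for them only; others in the source may bear on it.

The shared core carries an ether chain ending in a carboxylic acid and a phenyl group bearing one substituent or none. In an assay on membranes from spleen (Cavia porcellus) for binding affinity to leukotriene B4 receptor 1 (Homo sapiens) (a lower number here means a stronger inhibitor, a higher number a weaker inhibitor), compound 1 `CC(CCCCOc1cc(-c2ccccc2)c2ccccc2n1)C(=O)O` gives 550 nM, compound 2 `O=C(O)CCCCCOc1cc(-c2ccc(Cl)cc2)c2ccccc2n1` gives 30 nM, and compound 3 `CC(C)(CCCCOc1cc(-c2ccc(Cl)cc2)c2ccccc2n1)C(=O)O` gives 15 nM. Among the compounds with values here, compound 3 has the lowest of the three numbers; compound 2 is nearest, and the only single-place step measured so far, a 2.0-fold lower number from compound 2 to compound 3 (0.30 log units; within the scatter), lies within the scatter. Compound 1 is furthest from compound 3, but the two differ in two places, so their values are compared only as they stand.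

Compound 4 `CC(C)(CCCCOc1cc(-c2ccc(N)cc2)c2ccccc2n1)C(=O)O` differs from compound 3 by amino in place of chloro on an aromatic carbon. Within the data shown here, no measured step touches this ring position: the one step known concerns the chain end, and compounds 1 and 2 are not a single-place pair. Among the measured compounds shown here, the change therefore rests on no precedent, and the expected step of a 3.0-fold higher number from compound 3 to compound 4 (0.48 log units; beyond the scatter) in this assay is given a wide range around a modest rise. For compound 4 the estimate is 45 nM, with a range from 10 nM to 200 nM.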

Compound 4, half-maximal inhibitory concentration: 40 nM
For compound 4 the middle estimate is 1.1-fold (0.05 log units) above the measured one; the range from low to high includes it.
By their numbers in this assay, from the lowest: compounds 3, 2 and 4 (each within the scatter of the next, the first and the last beyond it); then compound 1.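

Within the data shown here, the 4-chlorophenyl to 4-aminophenyl change provides the first single-place reading at this ring position: in this assay, there is a 2.7-fold higher number from compound 3 to compound 4 (0.43 log units; beyond the scatter). This step is modest but lies beyond the scatter, unlike a 2.0-fold lower number from compound 2 to compound 3 (0.30 log units; within the scatter) at the chain end, so the position para to a large group does register this exchange, while compound 4 still gives 40 nM with amino in place of chloro. Nothing measured here accounts for the size or direction of the step.

The compounds shown leave open how a hydroxyl, a methoxy or a fluoro group at this place would compare with chloro and amino, and whether a single exchange of this kind reflects the position more widely. They also leave open what a bare phenyl ring contributes on the chain of compound 3, as compound 3 differs from compound 1 in two places and the value of compound 1, 550 nM, cannot be assigned to either change alone.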